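Thiol quinazolines in HT-29 cells: a methoxy step

A few compounds are considered here, and "the series" means these few. Any claim that something is new, unique, unknown or untested is made for them only; others in the source may bear on it.

Measured so far:
compound 1 `COc1ccc(CNc2nc([SeH])nc3ccccc23)cc1` — > 100000 nM
compound 2 `Sc1nc(NCc2ccccc2)c2ccccc2n1` — 63500 nM

Within the data shown here, in a functional assay on HT-29 cells (Homo sapiens) for cytotoxicity, read by MTT assay, with a stated time of 72 h (on this read-out higher numbers stand for weaker inhibition of growth and lower numbers for stronger inhibition of growth), compound 2 gives 63500 nM, the only number in the set. Compound 1 reaches only a limit of the assay, > 100000 nM (the limit of > 100000 nM in this assay, at which 1 of the 2 values shown sits). Compound 3 `COc1ccc(CNc2nc(S)nc3ccccc23)cc1` differs from compound 2 by methoxy in place of hydrogen on an aromatic carbon. Among the measured compounds shown here, no measured step covers this change. Given that compound 1, which also carries the methoxy group, sits at the limit > 100000 nM, compound 3 is expected to shift toward weaker growth inhibition, with the step of a 1.4-fold higher number from compound 2 to compound 3 (0.15 log units; within the scatter) likely modest. The estimate for compound 3 is 90000 nM, between 40000 nM and 200000 nM.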

Compound 3, concentration for total growth inhibition: 28600 nM
The estimate for compound 3 lay 3.1-fold (0.50 log units) above the measured number; measured number below the stated range.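

In this assay, methoxy in place of hydrogen on an aromatic carbon, para to a large group, gives a 2.2-fold lower number from compound 2 to compound 3 (0.35 log units; beyond the scatter), so the group at this position goes with stronger growth inhibition, not weaker. With methoxy held in place, one sulfur atom in place of one selenium atom gives an at least 3.4-fold lower number from compound 1 to compound 3 (0.54 log units; beyond the scatter). That step is a bound and not a size, as one end is a limit of the assay: the limit of > 100000 nM in this assay, at which 1 of the 3 values shown sits.

The compounds shown do not tell what an amine or a longer alkoxy chain would do on this carbon. They also leave open whether the methoxy step holds with selenium in place of sulfur.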